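Furan-3-yl in place of thiophen-2-yl on a nucleoside

The source may hold more compounds than are shown below. What is called first, only, known or untested is meant among the compounds shown, and "the series" means these compounds.

The shared core, shown in compound 3 `O=c1[nH]cnc2c1c(-c1cccs1)cn2[C@@H]1O[C@H](CO)[C@@H](O)[C@H]1O`, carries a thiophen-2-yl group on an aromatic carbon. In a functional assay on CEM-DNR-bulk cells (Homo sapiens), read by MTT assay, with a stated time of 72 h (a higher number here means a weaker inhibitor, a lower number a stronger inhibitor), compound 3 reaches only the limit of the assay, > 20000 nM. Its relative compound 2 `O=c1[nH]cnc2c1c(-c1cc3ccccc3o1)cn2[C@@H]1O[C@H](CO)[C@@H](O)[C@H]1O` bears a 1-benzofuran-2-yl group on that aromatic carbon. In this assay compound 2 likewise sits at a limit, > 20000 nM. Between the two the step is a step that the two limits leave unreadable from compound 2 to compound 3. Compound 1 `COc1nc(N)nc2c1c(-c1cc3ccccc3o1)cn2[C@@H]1O[C@H](CO)[C@@H](O)[C@H]1O` differs from compound 2 elsewhere than in this group and gives a number rather than a limit. In this assay compound 1 gives 16700 nM. Two of the three values shown sit at the limit of > 20000 nM in this assay, at which 2 of the 3 values shown sit, so compound 3 stands at the weak end of what the numbers can show.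

Compound 4 `O=c1[nH]cnc2c1c(-c1ccoc1)cn2[C@@H]1O[C@H](CO)[C@@H](O)[C@H]1O` is not yet measured. It differs from compound 3 by furan-3-yl in place of thiophen-2-yl on an aromatic carbon. Within the data shown here, the only measured step on this aromatic carbon was a step that the two limits leave unreadable from compound 2 to compound 3 and so gives no readable size. With no readable step bearing on the change, the expectation rests on where compound 3 stands. Compound 4 is expected to stay near the limit, with an estimated step that the limit leaves unreadable from compound 3 to compound 4. Compound 4 is estimated at 30000 nM, between 15000 nM and 80000 nM.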

Compound 4, half-maximal inhibitory concentration: > 20000 nM
Compound 4 ended at the assay's limit; the forecaster's own chance of this, stated with the estimate: 75%; the middle value does not contradict the limit.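

In this assay, among these compounds, compound 4 gives > 20000 nM, a limit and not a number, so no step among compound 2, compound 3 and compound 4 can be read: the limit of > 20000 nM in this assay, at which 3 of the 4 values shown sit. The compounds shown leave open how thiophen-2-yl, furan-3-yl and 1-benzofuran-2-yl compare on this aromatic carbon of the shared core.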